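Swapping trifluoromethyl for chloro on a urea-linked phenyl

The compounds below may be only part of what the source reports. "The series", "measured", "known", "first", "only" and "open" are said of these compounds alone.

Measured so far:
compound 1 `O=C(Nc1cccc(-n2cc(-c3ccncc3)c(-c3cc(O)cc(Cl)c3)n2)c1)Nc1ccc(Cl)c(Cl)c1`: 89%
compound 2 `COc1cc(Cl)cc(-c2nn(-c3cccc(NC(=O)Nc4ccc(Cl)c(C(F)(F)F)c4)c3)cc2-c2ccncc2)c1`: 83%

Of the compounds shown here, two sharing one core have been tested in a functional assay on SF-268 cells (Homo sapiens) for inhibition, read by sulforhodamine B assay, with a stated time of 48 h, tested at 1 uM; on this read-out higher numbers stand for a weaker effect at the one concentration tested and lower numbers for a stronger effect. Compound 1 gives 89% in this assay, and compound 2 gives 83%. The two numbers lie within the usual scatter of each other, so compound 2 stands alongside compound 1 with no separation that can be trusted; both show only a weak effect at the single concentration tested.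

Compound 3 `COc1cc(Cl)cc(-c2nn(-c3cccc(NC(=O)Nc4ccc(Cl)c(Cl)c4)c3)cc2-c2ccncc2)c1` has not been measured yet. It differs from compound 2 in one place: chloro in place of trifluoromethyl on an aromatic carbon. Compound 1, the other measured compound, already carries the 3,4-dichlorophenyl group that enters here, and its number sits next to that of compound 2. Among the compounds with values here, no step between measured compounds is available for this exact change, so there is no direct precedent to lean on. Given how close the two measured values are, the step from compound 2 to compound 3 is expected to be small, a number 3 percentage points higher from compound 2 to compound 3 (within the scatter), with no change beyond the scatter in either direction. Compound 3 is therefore estimated at 86%, within a range of 72% to 100%.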

Compound 3, a percentage reported as activity, at one concentration (the size of the read-out at that concentration, not a potency): 88%
Compound 3: the middle estimate sits 2 percentage points below what was measured; the measured number falls inside the stated range.
By their numbers in this assay, from the lowest: compounds 2, 3 and 1 (each within the scatter of the next).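

In this assay, putting chloro in place of trifluoromethyl on this aromatic carbon, ortho to a chloro group, gives a number 5 percentage points higher from compound 2 to compound 3 (within the scatter). So a single chlorine atom and a group of four heavy atoms cannot be told apart at this position, at least on this urea-linked phenyl with the methoxy-bearing ring held fixed. Within the data shown here, compound 3 also gives the first clean comparison on the oxygen of the other aromatic ring: with the 3,4-dichlorophenyl group held constant, methyl in place of hydrogen gives a number 1 percentage points lower from compound 1 to compound 3 (within the scatter), so that change cannot be separated from the scatter either. No measurement at hand offers an explanation for either of these two results.

The compounds shown cover only two small groups at the urea-linked position and only hydrogen or methyl on the oxygen, so it stays open whether an amine or a carboxylic acid on that aromatic carbon, or a longer chain on that oxygen, would shift the number beyond the scatter. Reading at one concentration also leaves open how these compounds would compare at other concentrations.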